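Side-chain exchange on the shared core: compound 3

A few compounds are considered here, and "the series" means these few. Any claim that something is new, unique, unknown or untested is made for them only; others in the source may bear on it.

Compound 1 `C=C1CC[C@@H]2[C@](C)(CCC[C@]2(C)C(=O)O)[C@H]1CC/C(C)=C/CO` carries the 4-hydroxy-2-methylbut-2-en-1-yl chain on the shared core. In a functional assay on SMMC-7721 cells (Homo sapiens) for cytotoxicity, read by MTT assay, with a stated time of 48 h (on this read-out higher numbers stand for weaker inhibition and lower numbers for stronger inhibition), compound 1 gives only a limit, > 40000 nM, so no number places it on the scale. Compound 2 `C=CC(=C)[C@@H](O)C[C@H]1C(=C)CC[C@@H]2[C@]1(C)CCC[C@]2(C)C(=O)O` is the other measured member of the series. In this assay compound 2 likewise gives only a limit, > 40000 nM. For the measured compounds named here, the one measured step, a step that the two limits leave unreadable from compound 1 to compound 2, is therefore unreadable, and the sole evidence is the limit of > 40000 nM in this assay, at which 2 of the 2 values shown sit.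

Compound 3 `C=CC(=C)[C@H](O)C[C@H]1C(=C)CC[C@@H]2[C@]1(C)CCC[C@]2(C)C(=O)O` is not yet measured. It differs from compound 1 by a group of 6 heavy atoms (5 carbon, 1 oxygen; no ring) in place of a group of 6 heavy atoms (5 carbon, 1 oxygen; no ring), on a saturated chain carbon bound to a saturated ring carbon. The measured step bearing on this exchange is a step that the two limits leave unreadable from compound 1 to compound 2, and it gives no readable size in either direction. On the values shown, compound 2 stands at the same limit as compound 1, which sets the expectation for compound 3.

Compound 3 is therefore expected to be reported as 40000 nM, with a range from 15000 nM to 100000 nM, most probably again as a limit rather than a number. The step this implies, a number no higher from compound 1 to compound 3 (the limit leaves the size open), is expected to be no change beyond the scatter.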

Compound 3, half-maximal inhibitory concentration: > 40000 nM
Compound 3 ended at the assay's limit; the forecaster's own chance of this, stated with the estimate: 80%; the middle value sits exactly at the limit.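

In this assay compound 3 gives > 40000 nM, a limit and not a number. The steps to compound 3 from compound 1 and from compound 2 therefore cannot be read: the limit of > 40000 nM in this assay, at which 3 of the 3 values shown sit.

Open is where any of the three compounds truly lies on the scale, and whether configuration at that saturated chain carbon matters: the fact that compounds 2 and 3 differ only in the configuration as drawn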